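The compounds below may be only part of what the source reports. "The series", "measured", "known", "first", "only" and "open" are said of these compounds alone.

Working notes on the series. Within the data shown here, in an ADME assay for permeability (a higher number here means that the compound crosses the layer faster, a lower number that the compound crosses the layer more slowly), compound 2 `CNC(=O)c1cc(C(=O)N[C@H]2CC[C@H](O)CC2)n([C@@H](C)c2cccc(Cl)c2)n1` gives 235 nm/s, the second highest of the three numbers so far. Compound 1 `CNC(=O)c1cc(C(=O)N[C@H]2[C@@H]3C[C@H](O)C[C@@H]32)n([C@@H](C)c2cccc(Cl)c2)n1` gives 333 nm/s in this assay; the change from compound 1 to compound 2 is a 1.4-fold lower number from compound 1 to compound 2 (0.15 log units; within the scatter), a swap on an amide-type nitrogen. Compound 3 `CNC(=O)c1cc(C(=O)NCCO)n([C@@H](C)c2ccccc2)n1` gives 59 nm/s in this assay; compound 3 differs from compound 2 in two places at once, so its gap to compound 2 cannot be assigned to either one.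

Compound 4 `CC[C@@H](c1ccccc1)n1nc(C(=O)NC)cc1C(=O)N[C@H]1CC[C@H](O)CC1` is to be measured in this assay. The change from compound 2 is 1-phenylpropyl in place of 1-(3-chlorophenyl)ethyl on an aromatic nitrogen. Among the measured compounds shown here, no measured step alters the group on the aromatic nitrogen alone, so nothing in the measured data bears directly on this change. For the measured compounds named here, the one single-site step, from compound 1 to compound 2, stayed within the scatter. Absent any step on the aromatic nitrogen, a change within the scatter is expected, and the step from compound 2 to compound 4 is estimated at a 1.0-fold lower number from compound 2 to compound 4 (0.01 log units; within the scatter). Compound 4 is therefore expected to give about 230 nm/s in this assay, with a range from 120 nm/s to 450 nm/s.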

Compound 4, apparent permeability: 70 nm/s
For compound 4 the middle estimate is 3.3-fold (0.52 log units) above the measured one; the whole stated range lies above it.
By their numbers in this assay, from the lowest: compounds 3 and 4 (each within the scatter of the next); then compounds 2 and 1 (each within the scatter of the next).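

In this assay, among these compounds, the group on the aromatic nitrogen now has a measured step of its own, a 3.4-fold lower number from compound 2 to compound 4 (0.53 log units; beyond the scatter), whereas the one earlier single-site step, on the amide-type nitrogen, stayed within the scatter. This position therefore registers a swap that leaves the group's heavy-atom count, hydrogen-bond donor and acceptor counts and net charge unchanged. Nothing at hand accounts for the size of this step.

The swap removes the chlorine and lengthens the chain in a single change, so the step cannot be divided between the two; 1-(3-chlorophenyl)propyl on the same nitrogen, with the rest of compound 2 kept, would separate them. On these data alone, how an amine or a carboxylic acid on this group would read in this assay also remains open.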